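A few compounds are considered here, and "the series" means these few. Any claim that something is new, unique, unknown or untested is made for them only; others in the source may bear on it.

Compound 1 `O=C(NC(=S)NNc1ncnc2ccccc12)c1ccc(C(F)(F)F)cc1`: 8050 nM
Compound 2 `COc1cc2ncnc(NNC(=S)NC(=O)c3ccc(F)cc3)c2cc1OC`: 25800 nM
Compound 3 `O=C(NC(=S)NNc1ncnc2ccccc12)c1cccc(Cl)c1`: 3540 nM

In a functional assay on MCF7 cells (Homo sapiens) for cytotoxicity, read by MTT assay, with a stated time of 72 h (a higher number here means a weaker inhibitor, a lower number a stronger inhibitor), compound 2 gives the highest number of the three and is thus the weakest inhibitor shown; compound 1 lies nearest to it and compound 3 furthest, both gaps beyond the scatter. Compound 4 `COc1cc2ncnc(NNC(=S)NC(=O)c3ccccc3OC)c2cc1OC` keeps the core of compound 2 and differs from it in one place: 2-methoxyphenyl in place of 4-fluorophenyl on a carbonyl carbon. Going by the values given here, no measured pair shows what this change does, so its size is unknown. Since one six-membered aromatic ring of carbon only replaces another, the estimated step in this assay is a 1.2-fold lower number from compound 2 to compound 4 (0.07 log units; within the scatter), expected to lie within the scatter. Compound 4 is therefore expected to give 22000 nM, with a range from 8000 nM to 60000 nM.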

Compound 4, half-maximal inhibitory concentration: 8800 nM
Beside the measured number, compound 4's estimate is 2.5-fold (0.40 log units) above it, within the range that was stated.
By their numbers in this assay, from the lowest: compound 3; then compounds 1 and 4 (each within the scatter of the next); then compound 2.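

Putting 2-methoxyphenyl in place of 4-fluorophenyl on a carbonyl carbon brings a 2.9-fold lower number from compound 2 to compound 4 (0.47 log units; beyond the scatter) in this assay and shows that the number responds to which aromatic ring sits at this position, although both groups are one six-membered aromatic ring of carbon only. The step is modest, and the data offer no explanation for it. As far as these compounds go, it remains open whether the same change would act similarly on the core of compound 1, and whether an amine or a carboxylic acid on this ring would move the number further.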